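Working notes: chloro in place of methoxy, compound 3

The source may report more compounds than this note shows. Statements on the series, on what has been measured and on what is new or still open speak of the compounds shown alone.

Going by the values given here, compound 2 `COc1cccc(-c2cccc(NC3=NCCN3)c2C)c1` gives 43.7 nM in an assay for binding affinity to Adrenergic receptor alpha-1 (Rattus norvegicus); on this read-out higher numbers stand for weaker inhibition and lower numbers for stronger inhibition; it stands lowest of the two numbers measured so far, and its nearest neighbour is compound 1 `Cc1c(NC2=NCCN2)cccc1-c1ccccc1`, which in this assay gives 209 nM. Among the compounds with values here, the single measured step, a 4.8-fold lower number from compound 1 to compound 2 (0.68 log units; beyond the scatter), is beyond the scatter and modest in size. Compound 3 `Cc1c(NC2=NCCN2)cccc1-c1cccc(Cl)c1` is not yet measured; it differs from compound 2 by chloro in place of methoxy on an aromatic carbon. Within the data shown here, no measured step bears directly on this exchange: the step from compound 1 to compound 2 shows only that a methoxy on that aromatic carbon gave a lower number than hydrogen, and says nothing about chloro against methoxy. The expectation for compound 3 in this assay is therefore a step of a 1.6-fold higher number from compound 2 to compound 3 (0.20 log units; within the scatter), within or close to the scatter, with a somewhat higher number judged more likely than a lower one. Compound 3 is estimated at 70 nM, with a range from 25 nM to 200 nM.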

Compound 3, inhibition constant: 132 nM
Estimate against measurement, compound 3: 1.9-fold (0.28 log units) below; the range from low to high includes it.
By their numbers in this assay, from the lowest: compound 2; then compounds 3 and 1 (each within the scatter of the next).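

In this assay the aromatic carbon meta to a large group now carries two different groups that can each be compared with hydrogen, and they do not behave alike: the step for chloro lies within the scatter (a 1.6-fold lower number from compound 1 to compound 3 (0.20 log units; within the scatter)), so chloro cannot be told apart from hydrogen here. Exchanging methoxy for chloro gives a step beyond the scatter (a 3.0-fold higher number from compound 2 to compound 3 (0.48 log units; beyond the scatter)), so the lower number of compound 2 goes with methoxy and does not follow from placing just any group on this carbon. Nothing at hand explains why the two groups differ.

Going by these compounds, it remains open whether a hydroxy, an ethoxy or an amine on this carbon would read like compound 2 or like compound 1. Also open, on these data alone, is whether methoxy on another carbon of the same ring would give a similar step.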